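Swapping furan-2-yl for naphthalen-1-yl in a cytotoxicity series

This account rests on a few compounds, and the source may have more. Where it says the series, first, only, none or still open, it means among the compounds named here.

Of the compounds shown here, two sharing one core have been measured in an ADME assay on HEK-293T cells (Homo sapiens) for cytotoxicity, read by MTT assay, with a stated time of 72 h, tested at 50 uM; a higher number here means more inhibition at the concentration tested (going by the name of the read-out), a lower number less inhibition. Compound 1 `O=C(Cn1c(-c2ccccc2)cc(-c2ccccc2)c1-c1ccco1)Nc1nc2ccccc2s1` gives 89.9%, and compound 2 `O=C(Cn1c(-c2ccccc2)cc(-c2ccco2)c1-c1ccco1)Nc1nc2ccccc2s1` gives 65.1%. Within the data shown here, the one step between them, a number 24.8 percentage points lower from compound 1 to compound 2 (beyond the scatter), is the only measured change at this position. On the numbers shown, compound 2 stands lowest of the two, with compound 1 the nearest neighbour at a number beyond the scatter above it.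

Compound 3 `O=C(Cn1c(-c2ccccc2)cc(-c2cccc3ccccc23)c1-c1ccco1)Nc1nc2ccccc2s1` has not yet been measured. It differs from compound 2 in one place: naphthalen-1-yl in place of furan-2-yl on an aromatic carbon. The step from compound 1 to compound 2 bears on this change, since it too exchanges the group on that same aromatic carbon; there the exchange of phenyl for furan-2-yl lowered the number by a modest amount. Compound 3 now removes the furan-2-yl again, this time for an all-carbon bicyclic ring, so a rise back toward the number of compound 1 is expected, estimated as a number 18.9 percentage points higher from compound 2 to compound 3 (beyond the scatter). The expected value for compound 3 is therefore 84%, within a range from 64% to 99%.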

Compound 3, a percentage reported as inhibition, at one concentration (the size of the read-out at that concentration, not a potency): 68.8%
Compound 3: middle estimate off by 15.2 percentage points, on the high side; measured number inside the range.
By their numbers in this assay, from the lowest: compounds 2 and 3 (each within the scatter of the next); then compound 1.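

In this assay, naphthalen-1-yl in place of furan-2-yl on this aromatic carbon gives a number 3.7 percentage points higher from compound 2 to compound 3 (within the scatter), so a group of two six-membered carbon rings and a five-membered ring with one oxygen cannot be told apart here, despite their different heavy-atom counts. Against phenyl on the same carbon, naphthalen-1-yl gives a number 21.1 percentage points lower from compound 1 to compound 3 (beyond the scatter), which shows that a ring of carbon only does not by itself restore the number of compound 1; among these three groups, phenyl alone stands apart from the other two. Nothing measured here accounts for why phenyl differs from both furan-2-yl and naphthalen-1-yl at this position.

The compounds shown leave open how groups of another kind would behave on this carbon, such as an amine, a carboxylic acid or a short alkyl chain, and whether a phenyl carrying a methoxy group would stay with compound 1 or fall with compound 2 and compound 3. They also leave open whether the same exchanges would give similar steps at the other ring positions of the shared core.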